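Thiophene for Pyridine on a Weakly Cytotoxic Core

The source may hold more compounds than are shown below. What is called first, only, known or untested is meant among the compounds shown, and "the series" means these compounds.

In a functional assay on T47D cells (Homo sapiens) for cytotoxicity, read by CCK-8 assay and cell counting, with a stated time of 2 days (on this read-out higher numbers stand for weaker inhibition and lower numbers for stronger inhibition), compound 1 `Oc1ccc(-c2cc(-c3ccc(Cl)cc3)nc(-c3cccnc3)c2)cc1` gives 29300 nM, the highest of the two numbers measured. Its nearest neighbour, compound 2 `Oc1cccc(-c2cc(-c3ccc(Cl)cc3)nc(-c3cccnc3)c2)c1`, gives 18100 nM in this assay. Going by the values given here, the only step between measured compounds, a 1.6-fold lower number from compound 1 to compound 2 (0.21 log units; within the scatter), concerns a different place on the shared core and so does not bear directly on the change at hand. Compound 3 `Oc1ccc(-c2cc(-c3ccc(Cl)cc3)nc(-c3ccsc3)c2)cc1` has not yet been measured; it differs from compound 1 by thiophen-3-yl in place of pyridin-3-yl on an aromatic carbon. Among the compounds with values here, no measured step addresses this exchange of one ring for another at that place, and the single step that does exist lies within the scatter. The size of step expected in this assay is therefore none beyond the scatter, with no direction assigned. The estimate for compound 3 is 29000 nM, with a range from 10000 nM to 85000 nM. This corresponds to an expected step of a 1.0-fold lower number from compound 1 to compound 3 (0.00 log units; within the scatter).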

Compound 3, half-maximal inhibitory concentration: 5490 nM
Estimate against measurement, compound 3: 5.3-fold (0.72 log units) above, outside the stated range (below it).
By their numbers in this assay, from the lowest: compound 3; then compounds 2 and 1 (each within the scatter of the next).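

In this assay this position, on an aromatic carbon next to the ring nitrogen, proves responsive to the ring it carries: thiophen-3-yl in place of pyridin-3-yl gives a 5.3-fold lower number from compound 1 to compound 3 (0.73 log units; beyond the scatter) and so a step beyond the scatter, which the move from 4-hydroxyphenyl to 3-hydroxyphenyl did not give (a 1.6-fold lower number from compound 1 to compound 2 (0.21 log units; within the scatter)). The change replaces a six-membered aromatic ring holding nitrogen with a five-membered aromatic ring holding sulfur, so ring size and hetero atom change together and these compounds cannot separate the two. Nothing available here accounts for the step.

The compounds shown leave open whether a phenyl ring, a furan-3-yl group or an amine at this place would follow compound 3. They also leave open whether thiophen-3-yl would bring a similar step on the core of compound 2.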